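A few compounds are considered here, and "the series" means these few. Any claim that something is new, unique, unknown or untested is made for them only; others in the source may bear on it.

Measured compounds in a functional assay for inhibition, with Homo sapiens as the target; a lower number here means a stronger inhibitor, a higher number a weaker inhibitor:
- compound 1 `Cc1nc(C)n2c(S)nncc12` gives only a limit of the assay, > 48000 nM
- compound 2 `CCOC(=O)CSc1nncc2c(C)nc(C)n12` gives only a limit of the assay, > 48000 nM
- compound 3 `C=CCSc1nncc2c(C)nc(C)n12` gives 59000 nM

Compound 2 thus stands at a limit in this assay, as does compound 1, with the limit of > 48000 nM in this assay, at which 2 of the 3 values shown sit. The measured steps say little: a step that the two limits leave unreadable from compound 1 to compound 2, a step that the limit leaves unreadable from compound 1 to compound 3 and a step that the limit leaves unreadable from compound 2 to compound 3 all fall where at least one limit keeps the size from being read. None of them touches the position changed here.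

Compound 4 `CCOC(=O)CSc1nncc2c(C)ncn12` differs from compound 2 by hydrogen in place of methyl on an aromatic carbon. For the measured compounds named here, no measured step bears on this change, so no shift beyond the scatter can be expected for it in this assay. Compound 4 is therefore estimated at 60000 nM (range 30000 nM to 150000 nM), a step that the limit leaves unreadable from compound 2 to compound 4, with a limit the most likely read-out.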

Compound 4, half-maximal inhibitory concentration: > 48000 nM
Compound 4 gave a limit, no number (the forecaster's own chance of this, stated with the estimate: 80%); the middle value lies beyond the limit too.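

Compound 2 and compound 4 both give only a limit, and the step between them cannot be read. The compounds shown leave open whether hydrogen in place of methyl on this aromatic carbon shifts the read-out in this assay at all.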